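Taking a hydroxy group from compound 3

The compounds below may be only part of what the source reports. "The series", "measured", "known", "first", "only" and "open" are said of these compounds alone.

In a functional assay on HEL cells (Homo sapiens) for cytotoxicity (on this read-out lower numbers stand for higher toxicity in this test and higher numbers for lower toxicity in this test), compound 3 (`CCCCCCC#Cc1cc2cn([C@@H]3O[C@H](CO)[C@@H](O)[C@H]3O)c(=O)nc2o1`) gives only a limit (> 133000 nM). Compound 1 (`CCCCC#Cc1cc2cn([C@@H]3O[C@H](CO)[C@@H](O)[C@H]3O)c(=O)nc2o1`) likewise gives only a limit (> 144000 nM). Among the compounds with values here, the one measured step (a step that the two limits leave unreadable from compound 1 to compound 3) therefore offers no size to carry over. Compound 4 (`CCCCCCC#Cc1cc2cn([C@H]3C[C@H](O)[C@@H](CO)O3)c(=O)nc2o1`) has hydrogen in place of hydroxy on a saturated ring carbon. Compound 2 (`CCCCCCCCCCC#Cc1cc2cn([C@H]3C[C@H](O)[C@@H](CO)O3)c(=O)nc2o1`) also lacks that hydroxy group, carries a longer chain and gives a true number (36000 nM). On that value of compound 2, a modest move toward higher toxicity is expected, though the result may again be only a limit. The expected step is modest (an at least 1.6-fold lower number from compound 3 to compound 4 (0.22 log units; that floor lies within the scatter)). In this assay compound 4 is estimated at 80000 nM (range 30000 nM to 200000 nM).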

Compound 4, half-maximal cytotoxic concentration: 138000 nM
Compound 4: the middle estimate sits 1.7-fold (0.24 log units) below what was measured; measured number inside the range.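

In this assay compound 4, with hydrogen in place of hydroxy on the saturated ring carbon, gives a true number (138000 nM). With that hydroxy group absent, chain length moves the read-out, and compound 4, which lacks the butyl of compound 2, shows a modest step beyond the scatter (a 3.8-fold higher number from compound 2 to compound 4 (0.58 log units; beyond the scatter)). Compound 3 gives only a limit, so the step at this ring carbon cannot be read: the limit of > 133000 nM in this assay, at which 1 of the 4 values shown sits.

The compounds shown leave open what this hydroxy group does on the longer chain of compound 2. They also leave open what an amine or a fluorine at this ring carbon would give.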